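The source may report more compounds than this note shows. Statements on the series, on what has been measured and on what is new or still open speak of the compounds shown alone.

In a functional assay on QG-56 cells (Homo sapiens) for antiproliferative activity (on this read-out higher numbers stand for weaker inhibition and lower numbers for stronger inhibition), the measured compounds stand as follows.

- compound 1 `Cn1cncc1C(O)(c1ccc([N+](=O)[O-])cc1)c1cc2cc([N+](=O)[O-])cc(-c3ccccc3)c2o1` gives 547 nM as a number
- compound 2 `Cn1cncc1C(O)(c1ccc(Cl)cc1)c1cc2cc([N+](=O)[O-])cc(-c3ccccc3)c2o1` gives 1890 nM as a number
- compound 3 `Cn1cncc1C(O)(c1ccc(I)cc1)c1cc2cc([N+](=O)[O-])cc(-c3ccccc3)c2o1` gives > 10000 nM as a limit of the assay

Compound 3 stands at the limit of > 10000 nM in this assay, at which 1 of the 3 values shown sits, and so carries a limit, not a number. The open step leads to compound 4 `Cn1cncc1C(O)(c1ccc(C(=O)O)cc1)c1cc2cc([N+](=O)[O-])cc(-c3ccccc3)c2o1` with carboxy in place of iodo on an aromatic carbon, para to a large group (carboxy in place of iodo on an aromatic carbon). Three measured steps at this same place bear on it: a 3.5-fold higher number from compound 1 to compound 2 (0.54 log units; beyond the scatter) is modest, an at least 18-fold higher number from compound 1 to compound 3 (1.26 log units; beyond the scatter) is large and an at least 5.2-fold higher number from compound 2 to compound 3 (0.72 log units; beyond the scatter) is at least modest. Among the compounds with values here, neither other group tried here stays at the limit, yet no measured compound carries carboxy, so the size of the step is uncertain and a second limit remains possible. A move to a lower number is expected, of modest size, by analogy with compound 2 and an at least 5.2-fold higher number from compound 2 to compound 3 (0.72 log units; beyond the scatter) as the smaller of the two steps away from iodo. The expected step is an at least 2.5-fold lower number from compound 3 to compound 4 (0.39 log units; beyond the scatter) on this estimate. For compound 4 the estimated value is 4000 nM with an expected range from 800 nM to 20000 nM in this estimate.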

Compound 4, half-maximal inhibitory concentration: > 10000 nM
Compound 4: no number, only a limit (the forecaster's own chance of this, stated with the estimate: 35%); middle value at least 2.5-fold (0.39 log units) away from the limit.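

In this assay, within the data shown here, compound 4 carries a limit, not a number, so iodo is no longer the only group at this aromatic carbon without a readable value: the limit of > 10000 nM in this assay, at which 2 of the 4 values shown sit. The series now shows an at least 5.2-fold higher number from compound 2 to compound 4 (0.72 log units; beyond the scatter) and an at least 18-fold higher number from compound 1 to compound 4 (1.26 log units; beyond the scatter), which places carboxy, like iodo, behind both chloro and nitro at this carbon. With compound 3 and compound 4 both at a limit, the step between them cannot be read, and no order between iodo and carboxy follows.

Still open, going by these compounds, is whether a methyl ester, a primary amide or a nitrile in place of carboxy on this carbon would return a measurable number. Also open, on these data alone, is whether an amine or a fluoro group here would fall nearer nitro, nearer chloro or at the limit.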